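From 3-Chlorobenzyl to 4-Fluorobenzyl: What to Expect

A few compounds are considered here, and "the series" means these few. Any claim that something is new, unique, unknown or untested is made for them only; others in the source may bear on it.

Compound 1, `CC1=C(C(=O)Nc2ccc(F)cc2)C(c2ccc([N+](=O)[O-])cc2)N=C(SCc2ccccc2)N1`, gives 7.2% in a functional assay on the whole organism (artery, strain albino) with Rattus norvegicus as the target, with a stated time of 30 min, at a dose of 10 mg/kg by the oral route; a lower number here means less inhibition, a higher number more inhibition at the dose given (going by the name of the read-out).
Compound 2, `CC1=C(C(=O)Nc2ccc(Br)cc2)C(c2ccc(Cl)cc2Cl)N=C(SCc2cccc(Cl)c2)N1`, gives 3.1% in this assay.

Both measured compounds show little inhibition in this assay, and the value of compound 2 sits within the scatter of the value of compound 1, so neither can be called weaker or stronger. Compound 3, `CC1=C(C(=O)Nc2ccc(Br)cc2)C(c2ccc(Cl)cc2Cl)N=C(SCc2ccc(F)cc2)N1`, differs from compound 2 in one place: 4-fluorophenyl in place of 3-chlorophenyl on a saturated chain carbon bound to a sulfur. Among the compounds with values here, no measured pair shows what this change does, so the expectation rests on the two values alone. The step of a number 1.9 percentage points higher from compound 2 to compound 3 (within the scatter) is expected to stay within the scatter. Compound 3 is estimated at 5%, with a range from -5% to 15%.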

Compound 3, a percentage reported as inhibition, in the whole organism at one dose (the size of the read-out at that dose, not a potency): 7.7%
The estimate for compound 3 lay 2.7 percentage points below the measured number; the range from low to high includes it.
By their numbers in this assay, from the lowest: compounds 2, 1 and 3 (each within the scatter of the next).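

In this assay, the change from 3-chlorobenzyl to 4-fluorobenzyl gives a number 4.6 percentage points higher from compound 2 to compound 3 (within the scatter), so the two compounds cannot be told apart at this dose. Within the data shown here, this is the first pair that differs in only one place, and it gives a direct reading for this position, though for this single exchange only. Nothing measured here offers an explanation for the result. From the compounds shown here alone, whether a longer chain or a carboxylic acid in place of these benzyl groups would give a number beyond the scatter remains open.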